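Pyrazole series: methoxy-to-hydroxy step toward compound 4

This account rests on a few compounds, and the source may have more. Where it says the series, first, only, none or still open, it means among the compounds named here.

Measured in a functional assay on UO-31 cells (Homo sapiens) for cytotoxicity, read by sulforhodamine B assay, with a stated time of 48 h, tested at 100 nM; a lower number here means a stronger effect, a higher number a weaker effect of the compound at the concentration tested:
compound 1, `COc1cc(C)cc(-c2nn(CC#N)cc2-c2ccc(-c3cccc(C(C)=O)c3)nc2)c1`, gives 79%
compound 2, `Cc1cc(O)cc(-c2nn(CC#N)cc2-c2ccnc(-c3ccc(Oc4ccccc4)cc3)c2)c1`, gives 85%
compound 3, `COc1cc(C)cc(-c2nn(CC#N)cc2-c2ccnc(-c3ccc(N(C)C)cc3)c2)c1`, gives 39%

Compound 3 stands lowest of the three numbers in this assay, and so shows the strongest effect at the concentration tested; the gap to compound 1, the nearest, and to compound 2, the furthest, each lies beyond the scatter. Going by the values given here, no two of the measured compounds differ in one place only, so no measured step is available for the change now in question.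

Compound 4, `Cc1cc(O)cc(-c2nn(CC#N)cc2-c2ccnc(-c3ccc(N(C)C)cc3)c2)c1`, differs from compound 3 by hydrogen in place of methyl on an oxygen on an aromatic ring. Compound 2 carries the same hydroxy and gives 85% in this assay, but it also differs from compound 3 elsewhere, so its value alone says little about this single change.

Among the compounds with values here, with no measured step to lean on, the expected step of a number 9 percentage points higher from compound 3 to compound 4 (within the scatter) is a modest rise in the number, possibly within the scatter; a large loss is not expected. For compound 4 the value expected in this assay is 48%, within a range from 25% to 75%.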

Compound 4, a percentage reported as activity, at one concentration (the size of the read-out at that concentration, not a potency): 82%
Compound 4: middle estimate off by 34 percentage points, on the low side, and the stated range ends below it.
By their numbers in this assay, from the lowest: compound 3; then compounds 1, 4 and 2 (each within the scatter of the next).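

In this assay the oxygen on the aromatic ring now has a measured single change: methoxy to hydroxy, that is 3-methoxy-5-methylphenyl to 3-hydroxy-5-methylphenyl, gives a number 43 percentage points higher from compound 3 to compound 4 (beyond the scatter), so with dimethylamino held constant the methyl on that oxygen cannot be lost without giving up the effect seen at the concentration tested. With the hydroxy held constant, dimethylamino in place of phenoxy on an aromatic carbon gives a number 3 percentage points lower from compound 2 to compound 4 (within the scatter), so in this pair dimethylamino does not bring back the effect. Within these two pairs, the low number of compound 3 goes with the methoxy and dimethylamino together, and dimethylamino with hydroxy in compound 4 does not reproduce it.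

On these data alone, whether the methoxy would matter as much with phenoxy in place of dimethylamino remains open, as does whether an ethoxy group or a fluorine atom on the same aromatic ring would keep the low number. No measurement at hand gives a reason for the size of this step.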